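The source may report more compounds than this note shows. Statements on the series, on what has been measured and on what is new or still open speak of the compounds shown alone.

Measured so far:
- compound 1, `CC(=O)c1cccc(NS(=O)(=O)c2ccc3nc(-c4ccccc4)c(-c4ccccc4)nc3c2)c1`, in an ADME assay on the whole organism for pharmacokinetics, with Homo sapiens as the target; on this read-out lower numbers stand for lower oral bioavailability and higher numbers for higher oral bioavailability: 96.9%
- compound 2, `O=S(=O)(Nc1ccc(Cl)cc1)c1ccc2nc(-c3ccccc3)c(-c3ccccc3)nc2c1`, in this assay: 100%

Compound 2 holds the higher of the two numbers, with compound 1 nearest; the step of a number 3.1 percentage points higher from compound 1 to compound 2 (within the scatter) is within the scatter. Compound 3, `Cc1ccnc(NS(=O)(=O)c2ccc3nc(-c4ccccc4)c(-c4ccccc4)nc3c2)c1`, differs from compound 2 by 4-methylpyridin-2-yl in place of 4-chlorophenyl on a sulfonamide nitrogen. Going by the values given here, the only measured step, a number 3.1 percentage points higher from compound 1 to compound 2 (within the scatter), concerns a different exchange on the same sulfonamide nitrogen, so no step bears directly on this change. For compound 3 the expected step is therefore a number 10 percentage points lower from compound 2 to compound 3 (within the scatter), none beyond the scatter. Compound 3 is estimated at 90%, with a range from 70% to 100%.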

Compound 3, oral bioavailability: 100%
The estimate for compound 3 lay 10 percentage points below the measured number; measured number inside the range.
By their numbers in this assay, from the lowest: compounds 1, 2 and 3 (each within the scatter of the next).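

Working notes: in this assay, exchanging the aryl group on the sulfonamide nitrogen now includes a ring with a hetero atom, 4-methylpyridin-2-yl, and this exchange gives no change at the digits printed from compound 2 to compound 3 (within the scatter). Against the 3-acetylphenyl group, the same group gives a number 3.1 percentage points higher from compound 1 to compound 3 (within the scatter), so all three groups on this nitrogen remain within the scatter of one another. Nothing available bears on the reason for this result.

As far as these compounds go, whether this holds for a non-aromatic group on the same nitrogen, such as a cyclohexyl group or a chain ending in a carboxylic acid, remains open. From the compounds shown here alone, the effect of any change on the shared core also remains open.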